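The compounds below may be only part of what the source reports. "The series", "measured", "known", "first", "only" and "open" are said of these compounds alone.

Measured compounds in a functional assay on A549 cells (Homo sapiens) for cytotoxicity, read by MTT assay, with a stated time of 48 h; on this read-out higher numbers stand for weaker inhibition and lower numbers for stronger inhibition:
compound 1 `C=C1C(=O)O[C@H]2CC3=C[C@H](C/C(C)=C/[C@@H](OC(=O)/C=C/c4cccc(OC)c4)[C@H]12)OC3=O`: 6200 nM
compound 2 `C=C1C(=O)O[C@H]2CC3=C[C@H](C/C(C)=C/[C@@H](OC(=O)CCCCBr)[C@H]12)OC3=O`: a limit of the assay, > 10000 nM
compound 3 `C=C1C(=O)O[C@H]2CC3=C[C@H](C/C(C)=C/[C@@H](OC(=O)C4CC4)[C@H]12)OC3=O`: 3200 nM

Compound 1 gives the highest of the two numbers on record in this assay. Its nearest neighbour is compound 3, and the step of a 1.9-fold lower number from compound 1 to compound 3 (0.29 log units; within the scatter) stays within the scatter, so the two cannot be ordered. For compound 2 only a limit is reported (the limit of > 10000 nM in this assay, at which 1 of the 3 values shown sits), and the step of an at least 1.6-fold higher number from compound 1 to compound 2 (0.20 log units; that floor lies within the scatter) therefore has only a floor. Between the two ester variants themselves the step of an at least 3.1-fold lower number from compound 2 to compound 3 (0.49 log units; beyond the scatter) is the one change in the series that reaches beyond the scatter.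

Compound 4 `C=C1C(=O)O[C@H]2CC3=C[C@H](C/C(C)=C/[C@@H](OC(=O)c4ccncc4)[C@H]12)OC3=O` differs from compound 1 in one place: pyridin-4-yl in place of 2-(3-methoxyphenyl)ethenyl on a carbonyl carbon. Going by the values given here, two measured steps bear on it, since both also exchange the 2-(3-methoxyphenyl)ethenyl group on the same carbonyl carbon: the step to compound 3 stays within the scatter, and the step to compound 2 ends at a limit. Neither measured step puts an aromatic group in this position, so no direction is supported. The step of a 1.1-fold lower number from compound 1 to compound 4 (0.05 log units; within the scatter) is expected to stay within the scatter. Compound 4 is therefore estimated at 5500 nM, with a range of 2500 nM to 10000 nM in this assay.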

Compound 4, half-maximal inhibitory concentration: > 10000 nM
Compound 4 was reported as a limit; the forecaster's own chance of this, stated with the estimate: 20%; at least 1.8-fold (0.25 log units) between middle value and limit.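

Compound 4 is the first ester in the series to carry an aromatic ring on this carbonyl carbon without an ethenyl group, and in this assay it is reported only as a limit: the limit of > 10000 nM in this assay, at which 2 of the 4 values shown sit.

The series now shows an at least 3.1-fold higher number from compound 3 to compound 4 (0.49 log units; beyond the scatter), which joins an at least 3.1-fold lower number from compound 2 to compound 3 (0.49 log units; beyond the scatter), so compound 3 with its cyclopropyl group has the lower number in both steps, and exchange at this position can move the read-out beyond the scatter. Against compound 1 the record gives only an at least 1.6-fold higher number from compound 1 to compound 4 (0.20 log units; that floor lies within the scatter), so replacing 2-(3-methoxyphenyl)ethenyl with pyridin-4-yl cannot be ordered firmly, and the step between compound 2 and compound 4 cannot be read at all, since both sit at the limit.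

The compounds shown do not separate the effect of the ring nitrogen in compound 4 from that of the shorter attachment of the ring, which a phenyl group at the same place would address. They also leave open whether a small ring other than cyclopropyl, such as cyclobutyl, would stay close to compound 3.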